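Swapping the Hydroxamate End for a Chloro Group

The source may report more compounds than this note shows. Statements on the series, on what has been measured and on what is new or still open speak of the compounds shown alone.

Measured so far:
compound 1 `CC(=O)ONC(=O)/C=C/c1ccccc1OC(=O)c1ccccc1`: 30200 nM
compound 2 `O=C(/C=C/c1ccccc1OC(=O)c1ccccc1)NOC(=O)c1ccccc1`: 8800 nM

In a functional assay on A549 cells (Homo sapiens) for inhibition, read by ELISA, with a stated time of 24 h (a higher number here means a weaker inhibitor of growth, a lower number a stronger inhibitor of growth), compound 1 gives 30200 nM, the highest of the two numbers and therefore the weaker inhibitor of the pair; compound 2 gives 8800 nM. Among the compounds with values here, the only measured step, a 3.4-fold lower number from compound 1 to compound 2 (0.54 log units; beyond the scatter), comes from a change at the carbonyl carbon.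

Compound 3 `O=C(Cl)/C=C/c1ccccc1OC(=O)c1ccccc1` differs from compound 1 at that same carbonyl carbon: chloro in place of acetoxyamino on a carbonyl carbon. Within the data shown here, the one measured step replaced a group at a different part of the molecule and on a different scale, so it gives little direct guidance here; no measured pair shows what a chloro group in place of acetoxyamino does. The expectation for compound 3 is therefore a step of a 1.0-fold lower number from compound 1 to compound 3 (0.00 log units; within the scatter), not beyond the scatter, with wide uncertainty. Compound 3 is estimated at 30000 nM, within a range of 8000 nM to 110000 nM.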

Compound 3, concentration for 50% growth inhibition: > 100000 nM
Compound 3: a limit, no number; the forecaster's own chance of this, stated with the estimate: 25%; middle value at least 3.3-fold (0.52 log units) from the limit.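

In this assay, chloro in place of acetoxyamino on the carbonyl carbon gives an at least 3.3-fold higher number from compound 1 to compound 3 (0.51 log units; beyond the scatter), so this change weakens growth inhibition. Compound 3 therefore carries a limit and not a number: the limit of > 100000 nM in this assay, at which 1 of the 3 values shown sits.

Within the data shown here, compound 1 and compound 2 both keep the nitrogen at this place and differ only further out, so compound 3 is the first to show what happens when the whole acetoxyamino group leaves.

On these data alone, how far compound 3 really lies from compound 1 stays unknown, since only a limit is available. As far as these compounds go, it also stays open whether the weaker result goes with losing the acetoxyamino group or with the arrival of chloro itself, a question that a carboxylic acid or a simple amino group on the same carbonyl carbon could help to separate.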